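From Acetamido to Carboxymethoxy on the Shared Core

This account rests on a few compounds, and the source may have more. Where it says the series, first, only, none or still open, it means among the compounds named here.

Measured so far in an assay on HeLa cells for inhibition of Indoleamine 2,3-dioxygenase 1 (Homo sapiens), read by spectrophotometry, with a stated time of 24 h; on this read-out lower numbers stand for an effect already at smaller amounts and higher numbers for an effect only at larger amounts of compound:
compound 1 `CC(=O)Nc1ccc(S(=O)(=O)NNc2ccc(Cl)cc2)cc1`: 142 nM
compound 2 `CC(=O)Nc1ccc(S(=O)(=O)NNc2ccc(Br)cc2)cc1`: 85 nM
compound 3 `CC(=O)Nc1ccc(S(=O)(=O)NNc2cccc(Br)c2)cc1`: 7560 nM

Compound 2 has the lowest number of the three in this assay. The step of a 1.7-fold lower number from compound 1 to compound 2 (0.22 log units; within the scatter) is within the scatter, so compounds 1 and 2 cannot be ordered; the steps of an 89-fold higher number from compound 2 to compound 3 (1.95 log units; beyond the scatter) and a 53-fold higher number from compound 1 to compound 3 (1.73 log units; beyond the scatter) are large and beyond the scatter.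

Compound 4 `O=C(O)COc1ccc(S(=O)(=O)NNc2ccc(Br)cc2)cc1` differs from compound 2 in one place: carboxymethoxy in place of acetamido on an aromatic carbon. Every measured step concerns the halogenated ring on the amine nitrogen; none touches the group para to the sulfonyl-bearing position, so the measured data give no direct guide for this change. With that in mind, compound 4 is estimated at 300 nM, with a range from 60 nM to 1500 nM. This estimate amounts to an expected 3.5-fold higher number from compound 2 to compound 4 (0.55 log units; beyond the scatter), a step whose direction is uncertain.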

Compound 4, half-maximal effective concentration: 152 nM
The estimate for compound 4 lay 2.0-fold (0.30 log units) above the measured number; the range from low to high includes it.
By their numbers in this assay, from the lowest: compounds 2, 1 and 4 (each within the scatter of the next); then compound 3.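

Going by these compounds alone, the earlier compounds varied only the halogenated ring, whereas this change is the first at the aromatic carbon para to a large group. In this assay, the step is a 1.8-fold higher number from compound 2 to compound 4 (0.25 log units; within the scatter), so acetamido and carboxymethoxy cannot be ordered at this place, although they differ in atom makeup. No measurement offered here accounts for this result. Still open, going by these compounds, is how an amine or a longer chain ending in a carboxylic acid would read at this place. Also open, on these data alone, is whether the exchange would read alike with 4-chlorophenyl or 3-bromophenyl on the amine nitrogen.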